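Nitro-amino phenyl substitution on the fused core: compound 4

The compounds below may be only part of what the source reports. "The series", "measured", "known", "first", "only" and "open" are said of these compounds alone.

Compound 3 `Cc1nc2c3ccccc3ccc2c2nc3c(ccc4ccccc43)c(-c3cccc4ccccc34)c12` stands second highest of the three numbers in a functional assay on HeLa cells (Homo sapiens) for cytotoxicity, read by MTT assay, with a stated time of 48 h (a higher number here means a weaker inhibitor, a lower number a stronger inhibitor), giving 14900 nM. Compound 1 `Cc1nc2c3ccccc3ccc2c2nc3c(ccc4ccccc43)c(-c3cccc([N+](=O)[O-])c3)c12` gives 50700 nM and compound 2 `Cc1nc2c3ccccc3ccc2c2nc3c(ccc4ccccc43)c(-c3nccnc3N)c12` gives 1210 nM; the step of a 3.4-fold lower number from compound 1 to compound 3 (0.53 log units; beyond the scatter) and the step of a 12-fold higher number from compound 2 to compound 3 (1.09 log units; beyond the scatter) frame where compound 3 sits. Compound 4 `Cc1nc2c3ccccc3ccc2c2nc3c(ccc4ccccc43)c(-c3cc([N+](=O)[O-])ccc3N)c12` carries 2-amino-5-nitrophenyl in place of naphthalen-1-yl on an aromatic carbon. Both measured steps bear on this: reversing a 3.4-fold lower number from compound 1 to compound 3 (0.53 log units; beyond the scatter) points toward a higher number, while the aminopyrazinyl of compound 2, seen in a 12-fold higher number from compound 2 to compound 3 (1.09 log units; beyond the scatter), suggests an amino group may pull the other way. A modest step upward, near the scatter, is expected: a 1.2-fold higher number from compound 3 to compound 4 (0.08 log units; within the scatter). Compound 4 is estimated at 18000 nM, within 4000 nM to 60000 nM.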

Compound 4, half-maximal inhibitory concentration: 5770 nM
For compound 4 the middle estimate is 3.1-fold (0.49 log units) above the measured one; low and high end bracket the measured number.
By their numbers in this assay, from the lowest: compound 2; then compound 4; then compound 3; then compound 1.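

In this assay, adding amino to the 3-nitrophenyl group of compound 1 is a change in one place that lowers the number (an 8.8-fold lower number from compound 1 to compound 4 (0.94 log units; beyond the scatter)), so this position responds to a substituent on the attached ring. The 2-amino-5-nitrophenyl group also gives a lower number than naphthalen-1-yl (a 2.6-fold lower number from compound 3 to compound 4 (0.41 log units; beyond the scatter)), yet a higher one than 3-aminopyrazin-2-yl (a 4.8-fold higher number from compound 2 to compound 4 (0.68 log units; beyond the scatter)). Nothing available explains these shifts. Open, on these data alone, is whether the nitro group contributes at all once the amino is present, and how a hydroxyl or methoxy would compare with the amino.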